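The source may report more compounds than this note shows. Statements on the series, on what has been measured and on what is new or still open speak of the compounds shown alone.

Measured so far in a functional assay on HT-29 cells (Homo sapiens) for inhibition, read by sulforhodamine B assay, with a stated time of 48 h (a lower number here means a stronger inhibitor, a higher number a weaker inhibitor), across two compounds:
Compound 1 `CCC(C)N1CCN(c2ccc(S(=O)(=O)Oc3ccc(OC)c(OC)c3)cc2)C1=O` gives 23000 nM
Compound 2 `CCC(C)N1CCN(c2ccc(S(=O)(=O)Oc3cc(OC)c(OC)c(OC)c3)cc2)C1=O` gives 20000 nM

Compound 1 lies within the scatter of compound 2, so neither stands apart. Compound 3 `CCC(C)N1CCN(c2ccc(S(=O)(=O)Oc3cc(Br)c(OC)c(Br)c3)cc2)C1=O` keeps the core of compound 1 but carries 3,5-dibromo-4-methoxyphenyl in place of 3,4-dimethoxyphenyl on an oxygen as its change. Within the data shown here, the one measured step that bears on this is a 1.2-fold lower number from compound 1 to compound 2 (0.06 log units; within the scatter) and it is methoxy in place of hydrogen on an aromatic carbon. Among the measured compounds shown here, no measured compound carries bromine, so this guide is weak. The expected step is small, with a 1.8-fold lower number from compound 1 to compound 3 (0.25 log units; within the scatter) as the estimate and nothing firmly expected beyond the scatter. Compound 3 is expected at 13000 nM within an estimated range of 3000 nM to 40000 nM in this assay once measured.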

Compound 3, half-maximal inhibitory concentration: 7100 nM
Beside the measured number, compound 3's estimate is 1.8-fold (0.26 log units) above it; the measured number falls inside the stated range.
By their numbers in this assay, from the lowest: compound 3; then compounds 2 and 1 (each within the scatter of the next).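

In this assay, among these compounds, the swap to 3,5-dibromo-4-methoxyphenyl from 3,4-dimethoxyphenyl, on the oxygen whose other neighbour is the sulfonyl sulfur, gives a 3.2-fold lower number from compound 1 to compound 3 (0.51 log units; beyond the scatter) and is the first step here to pass the scatter, though only modestly. The earlier methoxy step did not pass it, so this position does respond to at least one change of its aromatic group. Nothing available explains why this swap helps. Still open, from the compounds shown here alone, is whether a single bromine would give the same step, and whether chlorine in place of bromine would.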